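This account rests on a few compounds, and the source may have more. Where it says the series, first, only, none or still open, it means among the compounds named here.

Measured so far:
- compound 1 `C[C@H](O)CCNC(C)(C)C(=O)N[C@@H]1CCc2ccccc2N(Cc2ccc(-c3ccccc3-c3nn[nH]n3)cc2)C1=O` — 50 nM
- compound 2 `CO[C@H](C)CNC(C)(C)CC(=O)N[C@@H]1CCc2ccccc2N(Cc2ccc(-c3ccccc3-c3nn[nH]n3)cc2)C1=O` — 20 nM

In a functional assay (Pituitary gland cell) with Rattus norvegicus as the target (a higher number here means that more compound is needed for the effect, a lower number that less compound is needed), compound 1 gives 50 nM, while compound 2 gives 20 nM. Among the compounds with values here, compound 2 therefore holds the lowest number of the two measured; the only recorded step is a 2.5-fold lower number from compound 1 to compound 2 (0.40 log units; beyond the scatter), which alters the amine substituent and the spacing to the carbonyl at the same time.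

Compound 3 `CC(=O)O[C@@H](C)CNC(C)(C)CC(=O)N[C@@H]1CCc2ccccc2N(Cc2ccc(-c3ccccc3-c3nn[nH]n3)cc2)C1=O` is the next point in the series. It differs from compound 2 by 1-acetoxyethyl in place of 1-methoxyethyl on a saturated chain carbon bound to an amine nitrogen. Within the data shown here, no measured pair isolates this exchange: the single recorded step, a 2.5-fold lower number from compound 1 to compound 2 (0.40 log units; beyond the scatter), touches the oxygen-bearing substituent on the amine side chain but changes other parts alongside it, so it bears on the present change only loosely. The exchange keeps the stereocentre and the side-chain length of compound 2 and replaces one acceptor-bearing group with a larger one, so no direction is strongly indicated.

For compound 3 in this assay the expected step is a 1.5-fold higher number from compound 2 to compound 3 (0.18 log units; within the scatter), which should stay close to the scatter. The estimate for compound 3 is 30 nM, expected to fall between 10 nM and 90 nM.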

Compound 3, concentration for half-maximal effect: 200 nM
Compound 3: middle estimate off by 6.7-fold (0.82 log units), on the low side; the measured number lies above the stated range.
By their numbers in this assay, from the lowest: compound 2; then compound 1; then compound 3.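

In this assay, the substituent on a saturated chain carbon bound to an amine nitrogen proves sensitive to the exchange of 1-methoxyethyl for 1-acetoxyethyl: the stereocentre and side-chain length stay as in compound 2, yet the change gives a 10-fold higher number from compound 2 to compound 3 (1.00 log units; beyond the scatter). The side chain of compound 3 also compares unfavourably with that of compound 1, with a 4.0-fold higher number from compound 1 to compound 3 (0.60 log units; beyond the scatter), so the lower number reached with the 2-methoxypropyl side chain of compound 2 does not carry over to its 2-acetoxypropyl counterpart. No supporting evidence bears on the origin of this rise.

The compounds shown leave open whether the higher number follows the carbonyl of the acetoxy group or simply the larger substituent, and a 2-ethoxypropyl or 2-hydroxypropyl group on the same amine nitrogen would help separate those readings. They also leave open whether the opposite configuration at the stereocentre would shift the number in the methoxy or the acetoxy side chain.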